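This account rests on a few compounds, and the source may have more. Where it says the series, first, only, none or still open, it means among the compounds named here.

Values in a physicochemical assay for metabolic stability, read by HPLC and mass spectrometry, in phosphate buffer, at 37 degrees C, at pH 7.4; on this read-out lower numbers stand for a shorter-lived compound and higher numbers for a longer-lived compound:
- compound 1 `CC(C)(O/N=C(\C(=O)N[C@@H]1C(=O)N(S(=O)(=O)O)[C@@H]1CN1CCCCC1=O)c1csc(N)n1)C(=O)O`: 214 h
- compound 2 `CC(C)(O/N=C(\C(=O)N[C@@H]1C(=O)N(S(=O)(=O)O)[C@@H]1Cn1cc(CO)nn1)c1csc(N)n1)C(=O)O`: > 37 h

Compound 2 has no numerical value in this assay, only the limit > 37 h. This is the limit of > 37 h in this assay, at which 1 of the 2 values shown sits. Its place relative to compound 1 therefore cannot be fixed.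

The next compound is compound 3 `CC(C)(O/N=C(\C(=O)N[C@@H]1C(=O)N(S(=O)(=O)O)[C@@H]1Cn1ncnc1CN)c1csc(N)n1)C(=O)O`. It keeps the core of compound 2 and differs from it as follows: a group of 7 heavy atoms (3 carbon, 4 nitrogen; one five-membered aromatic ring with 3 hetero atoms) in place of a group of 7 heavy atoms (3 carbon, 3 nitrogen, 1 oxygen; one five-membered aromatic ring with 3 hetero atoms), on a saturated chain carbon bound to a saturated ring carbon. In words, a group of 7 heavy atoms (3 carbon, 4 nitrogen; one five-membered aromatic ring with 3 hetero atoms) replaces 4-(hydroxymethyl)-1H-1,2,3-triazol-1-yl, on a saturated chain carbon bound to a saturated ring carbon.

Among the compounds with values here, only one measured step bears on this change: a step that the limit leaves unreadable from compound 1 to compound 2. It gives neither a size nor a direction, so the data offer no basis for predicting a shift. The expected step is a step that the limit leaves unreadable from compound 2 to compound 3, with no change beyond the scatter anticipated.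

Within the data shown here, the only numerical anchor is compound 1, at 214 h. A result for compound 3 reported only as a limit would not be surprising. Compound 3 is expected to show a half-life of about 80 h, with an estimated range of 30 h to 220 h.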

Compound 3, half-life: > 37 h
Compound 3 gave a limit, no number; the forecaster's own chance of this, stated with the estimate: 35%; the middle value lies beyond the limit too.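

In this assay compound 3 gives only a limit, > 37 h. Within the data shown here, no step among compound 1, compound 2 and compound 3 can be read from this result. The compounds shown leave open whether the half-lives of compound 2 and compound 3 differ from each other or from that of compound 1: the limit of > 37 h in this assay, at which 2 of the 3 values shown sit.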